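A Limit Reading and a Changed Side Chain

The source may report more compounds than this note shows. Statements on the series, on what has been measured and on what is new or still open speak of the compounds shown alone.

In a functional assay on HCT-116 cells (Homo sapiens) for inhibition, read by MTT assay, with a stated time of 72 h (a higher number here means a weaker inhibitor of growth, a lower number a stronger inhibitor of growth), compound 1 `CNC(=O)/C=C/c1ccncc1-c1ccc2cccnc2c1` stands as "not determined" (no result reported), so it offers no figure for comparison. Compound 2 `NNC(=O)CCc1ccncc1-c1ccc2ccccc2c1` reads > 30000 nM in this assay, and this is a limit of the assay rather than a number. Going by the values given here, no measured step is available to show how far a structural change can move this read-out. Compound 3 `O=C(O)/C=C/c1ccncc1-c1ccc2ccccc2c1` carries 2-carboxyethenyl in place of 2-(aminocarbamoyl)ethyl on an aromatic carbon, ortho to a large group and opposite the ring nitrogen (2-carboxyethenyl in place of 2-(aminocarbamoyl)ethyl on an aromatic carbon). The expectation rests on compound 2 alone, with its limit of > 30000 nM. No change beyond the scatter is expected in this assay, and the estimated move is a number no higher from compound 2 to compound 3 (the limit leaves the size open). In this assay the estimate for compound 3 is 30000 nM, with an expected range from 12000 nM to 60000 nM.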

Compound 3, concentration for 50% growth inhibition: > 30000 nM
Compound 3 was reported as a limit (the forecaster's own chance of this, stated with the estimate: 70%); the middle value lies on the limit itself.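

Compound 2 and compound 3 are both reported only as limits, so no step between them can be read: the limit of > 30000 nM in this assay, at which 2 of the 3 values shown sit.

The compounds shown leave open what single value either compound has in this assay, and so whether 2-carboxyethenyl and 2-(aminocarbamoyl)ethyl differ there at all.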